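A few compounds are considered here, and "the series" means these few. Any claim that something is new, unique, unknown or untested is made for them only; others in the source may bear on it.

Compound 1 `Cc1ccc(-n2nncc2CN2C(=O)C3(C(C#N)=C(N)Oc4c3c3nc5ccccc5nc3c3ccccc43)c3ccccc32)cc1Cl`: > 50000 nM
Compound 2 `CC(=O)Nc1ccc(-n2nncc2CN2C(=O)C3(C(C#N)=C(N)Oc4c(N)cc5nc6ccccc6nc5c43)c3ccccc32)cc1`: > 50000 nM

Both numbers come from a functional assay on MCF7 cells (Homo sapiens) for antiproliferative activity, read by MTT assay, with a stated time of 48 h; on this read-out higher numbers stand for weaker inhibition and lower numbers for stronger inhibition. For compound 1 the value > 50000 nM is a limit of the assay, not a number. For compound 2 the value > 50000 nM is likewise only a limit. Compound 2 therefore stands at the limit of > 50000 nM in this assay, at which 2 of the 2 values shown sit, with nothing to separate it from its neighbour. Compound 3 `Cc1cc(C)c(-n2nncc2CN2C(=O)C3(C(C#N)=C(N)Oc4c(N)cc5nc6ccccc6nc5c43)c3ccccc32)c(C)c1` differs from compound 2 by 2,4,6-trimethylphenyl in place of 4-acetamidophenyl on an aromatic nitrogen. Within the data shown here, no step between measured compounds is known, so nothing here tells how far such a change can move the read-out. The expected step is a number no higher from compound 2 to compound 3 (the limit leaves the size open), and this expected step is none beyond the scatter. Compound 3 is estimated at 50000 nM, with a range from 20000 nM to 150000 nM.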

Compound 3, half-maximal inhibitory concentration: > 50000 nM
Compound 3: no number, only a limit; the forecaster's own chance of this, stated with the estimate: 75%; the middle value sits exactly at the limit.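

Among these compounds, compound 3 returns only a limit, as compound 2 does, so no step from compound 2 to compound 3 can be read. The compounds shown leave open how far changing the group on the aromatic nitrogen can move the read-out, as all of them stand at one point: the limit of > 50000 nM in this assay, at which 3 of the 3 values shown sit.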